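Phenyl in Place of Pyridin-3-yl: What to Expect

The source may hold more compounds than are shown below. What is called first, only, known or untested is meant among the compounds shown, and "the series" means these compounds.

Three compounds have been measured in an assay on CHO cells for displacement of a labelled ligand from adenosine receptor A1 (Homo sapiens), read by scintillation counting, tested at 10 uM; a lower number here means less inhibition, a higher number more inhibition at the concentration tested (going by the name of the read-out):
Compound 1 `COc1ccc(-c2sc(N)c(C(=O)c3ccc(Cl)cc3)c2C)cc1` gives 1%
Compound 2 `CC(C)(C)Cc1c(-c2cccnc2)sc(N)c1C(=O)c1ccc(Cl)cc1` gives 1%
Compound 3 `CC(C)(C)Cc1csc(N)c1C(=O)c1ccc(Cl)c(Cl)c1` gives 1%

Compound 2 stands level with compounds 1 and 3 at the digits shown; the three values lie within the usual scatter of one another, so none of them can be called stronger or weaker than the rest in this assay. Compound 4 `CC(C)(C)Cc1c(-c2ccccc2)sc(N)c1C(=O)c1ccc(Cl)cc1` has not yet been measured. It differs from compound 2 in one place: phenyl in place of pyridin-3-yl on an aromatic carbon. Among the compounds with values here, no step between two measured compounds is available, so the data give no measured size for a change of this kind. With every measured compound at the same low level, no step beyond the scatter is expected, and the step of a number 1 percentage points higher from compound 2 to compound 4 (within the scatter) is the estimate here. Compound 4 is therefore expected to give about 2% in this assay, with a likely range from 0% to 12%.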

Compound 4, a percentage reported as inhibition, at one concentration (the size of the read-out at that concentration, not a potency): 1%
Compound 4: middle estimate off by 1 percentage points, on the high side, within the range that was stated.
By their numbers in this assay, from the lowest: compounds 1, 2, 3 and 4 (each within the scatter of the next).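

Within the data shown here, compounds 2 and 4 give the first measured step at this position, on the aromatic carbon next to the ring sulfur: in this assay there is no change at the digits printed from compound 2 to compound 4 (within the scatter) when phenyl replaces pyridin-3-yl. Losing the ring nitrogen thus leaves the reading unmoved, although at so low a level this cannot tell whether that atom would matter in a compound with a higher reading. Nothing measured here offers an explanation for the result.

Still open, as far as these compounds go, is whether another group on this carbon, such as an amine or a carboxylic acid, would raise the reading.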